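This account rests on a few compounds, and the source may have more. Where it says the series, first, only, none or still open, it means among the compounds named here.

Measured compounds in a toxicity assay on MT2 cells (Homo sapiens) for cytotoxicity, read by XTT assay, with a stated time of 4 days; a higher number here means that more compound is tolerated, a lower number that less compound is tolerated:

compound 1, `Cc1nc(C)c([C@H](OC(C)(C)C)C(=O)O)c(N2CCC(C)(C)CC2)c1-c1ccc(Oc2ccccc2)cc1`: >= 20000 nM, a limit of this assay
compound 2, `Cc1nc(C)c([C@H](OC(C)(C)C)C(=O)O)c(N2CCC(C)(C)CC2)c1-c1ccc(OCCc2ccc(Cl)cc2)cc1`: >= 33500 nM, a limit of this assay
compound 3, `Cc1nc(C)c([C@H](OC(C)(C)C)C(=O)O)c(N2CCC(C)(C)CC2)c1-c1ccc(OC2CCCC2c2ccc(F)cc2)cc1`: >= 32000 nM; >= 32000 nM (2 entries), both entries a limit of this assay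

Compound 1 stands only at a limit in this assay; no single number is known for it, and the other two compounds likewise give limits only. For the measured compounds named here, the one measured step that touches compound 1, a step that the two limits leave unreadable from compound 1 to compound 2, is therefore not readable, since both ends sit at limits (the limit of >= 20000 nM in this assay, at which 1 of the 3 values shown sits, (the limit of >= 33500 nM in this assay, at which 1 of the 3 values shown sits)). Compound 3 adds a third limit at the upper edge of the tested range.

The next compound, compound 4, `Cc1nc(C)c([C@H](OC(C)(C)C)C(=O)O)c(N2CCC(C)(C)CC2)c1-c1ccc(OCCc2ccncc2)cc1`, differs from compound 1 as follows: 2-(pyridin-4-yl)ethyl in place of phenyl on an oxygen on an aromatic ring. The closest measured comparison is the step to compound 2, which shows no readable size. Nothing in the series gives a direction for this change, so no step beyond the scatter is expected; compound 4 is expected to sit at the tested ceiling as well, with an expected step that the limit leaves unreadable from compound 1 to compound 4. The estimate for compound 4 in this assay is 30000 nM, within the range 20000 nM to 50000 nM.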

Compound 4, half-maximal cytotoxic concentration: >= 25000 nM
Compound 4 gave a limit, no number (the forecaster's own chance of this, stated with the estimate: 85%); the middle value does not contradict the limit.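

Compound 4 gives only a limit in this assay, and the steps to it from compound 1 and from compound 2 cannot be read. The compounds shown leave open where the half-maximal cytotoxic concentration of any of them lies, and whether 2-(pyridin-4-yl)ethyl in place of phenyl changes it.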